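Piperidine side chain change on the methoxyphenyl series

The source may report more compounds than this note shows. Statements on the series, on what has been measured and on what is new or still open speak of the compounds shown alone.

Compound 1 `COc1cc(C2CCN(C[C@@H](C)O)CC2)ccc1Nc1ncc2ccc(-c3ccccc3N(C)S(C)(=O)=O)n2n1` gives only a limit in an in vitro ADME assay on microsomes from liver (Macaca mulatta) for metabolic stability, using NADPH, with a stated time of 10 min, tested at 0.5 uM (on this read-out higher numbers stand for a longer-lived compound and lower numbers for a shorter-lived compound), namely < 0.0834 h, a limit of the assay and not a number. Among the compounds with values here, compound 2 `COc1cc(C2CCN(C[C@@H](C)O)CC2)ccc1Nc1ncc2ccc(-c3ccccc3OC)n2n1` is the one compound with a number in this assay, where compound 2 gives 0.35 h. The step of an at least 4.1-fold higher number from compound 1 to compound 2 (0.62 log units; beyond the scatter) rests on one side on a limit, as noted in the limit of < 0.0834 h in this assay, at which 1 of the 2 values shown sits, so its true size is not known.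

Compound 3 `CNC(=O)CN1CCC(c2ccc(Nc3ncc4ccc(-c5ccccc5OC)n4n3)c(OC)c2)CC1` differs from compound 2 in methylcarbamoyl in place of 1-hydroxyethyl on a saturated chain carbon bound to an amine nitrogen in a ring. Within the data shown here, the single measured step alters the aromatic substituent and leaves the piperidine side chain untouched, so no measured step bears on this change. The expectation for compound 3 is therefore a step of no change at the digits printed from compound 2 to compound 3 (within the scatter) in this assay, not beyond the scatter in either direction. Compound 3 is estimated at 0.35 h, with a range from 0.15 h to 0.8 h.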

Compound 3, half-life: < 0.2 h
Compound 3: no number, only a limit (the forecaster's own chance of this, stated with the estimate: 10%); middle value at least 1.7-fold (0.24 log units) from the limit.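

The side chain at this place now has a measured change, the first one shown for the series. In this assay compound 3 gives < 0.2 h, which is a limit of the assay and not a number: the limit of < 0.2 h in this assay, at which 1 of the 3 values shown sits.

Replacing 1-hydroxyethyl with methylcarbamoyl gives an at least 1.7-fold lower number from compound 2 to compound 3 (0.24 log units; that floor lies within the scatter). Methylcarbamoyl therefore shows no gain over 1-hydroxyethyl at this place, and only the floor of the step is known, with the true size of the drop unresolved.

Still open, on these data alone, is whether the same change behaves alike on the core of compound 1, which carries methyl(methylsulfonyl)amino on the aromatic carbon. Also open, as far as these compounds go, is what a carboxylic acid or a longer chain ending in a primary amine would give in this assay at this place.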